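The source may hold more compounds than are shown below. What is called first, only, known or untested is meant among the compounds shown, and "the series" means these compounds.

In a functional assay on NCI-H460 cells (Homo sapiens) for inhibition, read by sulforhodamine B assay, with a stated time of 48 h (on this read-out lower numbers stand for stronger inhibition of growth and higher numbers for weaker inhibition of growth), compound 1 `O=C(NNC(=O)c1ccc2[nH]c(-c3ccc([N+](=O)[O-])o3)nc2c1)c1ccccc1` stands at 62.5 ug/mL in this series, level with compound 2 `COc1cc(C(=O)NNC(=O)c2ccc3[nH]c(-c4ccc([N+](=O)[O-])s4)nc3c2)cc(OC)c1OC` at 62.5 ug/mL and within the scatter of compound 3 `O=C(O)c1ccc2[nH]c(-c3ccc([N+](=O)[O-])o3)nc2c1` at 125 ug/mL on the same read-out. Among the measured compounds shown here, compound 4 `COc1ccc(C(=O)NNC(=O)c2ccc3[nH]c(-c4ccc([N+](=O)[O-])o4)nc3c2)cc1OC` has 3,4-dimethoxyphenyl in place of phenyl on a carbonyl carbon as its only change from compound 1. For the measured compounds named here, no pair of measured compounds isolates this change, so no step beyond the scatter is expected in this assay for it. Compound 2 also carries methoxy groups and reads 62.5 ug/mL with no separation from compound 1. The estimated step (no change at the digits printed from compound 1 to compound 4 (within the scatter)) stays within the scatter. Compound 4 is expected at 62.5 ug/mL with an estimated range from 31 ug/mL to 125 ug/mL in this series.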

Compound 4, concentration for 50% growth inhibition: 15.6 ug/mL
Compound 4: the middle estimate sits 4.0-fold (0.60 log units) above what was measured; measured number outside the range, below it.
By their numbers in this assay, from the lowest: compound 4; then compounds 1, 2 and 3 (each within the scatter of the next).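

In this assay, the position on a carbonyl carbon proves open to change: 3,4-dimethoxyphenyl in place of phenyl gives a 4.0-fold lower number from compound 1 to compound 4 (0.60 log units; beyond the scatter) and is the only step shown at this position. The larger group, with its two added oxygen atoms, is thus accepted here without any loss of growth inhibition. Nothing available explains the step.

On these data alone, whether one methoxy group alone would give the same step remains open. So does how an amine or a longer chain on this carbonyl carbon would read in this assay.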